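Swapping an Octyl Chain for a Difluorophenyl Ring

The source may hold more compounds than are shown below. What is called first, only, known or untested is meant among the compounds shown, and "the series" means these compounds.

Within the data shown here, compound 2, `CCCCCCCCc1cn(Cc2cc(=O)oc3cc(O)ccc23)nn1`, holds the only numerical value shown: in a functional assay on HepG2 cells (Homo sapiens) for inhibition, read by MTT assay, with a stated time of 72 h (on this read-out higher numbers stand for weaker inhibition and lower numbers for stronger inhibition), compound 2 gives 34200 nM. Compound 1, `CC(C)(C)c1cn(Cc2cc(=O)oc3cc(O)ccc23)nn1`, reaches only a limit of the assay, giving > 100000 nM in this assay. Among the measured compounds shown here, the single measured step, an at least 2.9-fold lower number from compound 1 to compound 2 (0.46 log units; beyond the scatter), concerns one alkyl chain replacing another, and its starting point rests at the limit of > 100000 nM in this assay, at which 1 of the 2 values shown sits. Compound 3, `O=c1cc(Cn2cc(-c3cc(F)cc(F)c3)nn2)c2ccc(O)cc2o1`, differs from compound 2 by 3,5-difluorophenyl in place of octyl on an aromatic carbon. For the measured compounds named here, no measured step compares an aromatic ring with a chain, so the step of a 1.2-fold higher number from compound 2 to compound 3 (0.07 log units; within the scatter) is expected to stay within or near the scatter. Compound 3 is estimated at 40000 nM, with a range from 10000 nM to 100000 nM.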

Compound 3, half-maximal inhibitory concentration: 38900 nM
Beside the measured number, compound 3's estimate is 1.0-fold (0.01 log units) above it; low and high end bracket the measured number.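

In this assay a ring can stand at this position on the five-membered ring in place of a chain with no change beyond the scatter: the swap of octyl for 3,5-difluorophenyl gives a 1.1-fold higher number from compound 2 to compound 3 (0.06 log units; within the scatter) and so leaves the two groups indistinguishable here. The same ring also compares with tert-butyl, giving an at least 2.5-fold lower number from compound 1 to compound 3 (0.41 log units; beyond the scatter) as its step. Compound 1 stands at a limit of the assay, so that step gives only a bound: the limit of > 100000 nM in this assay, at which 1 of the 3 values shown sits.

In this assay the compounds shown leave open how an amine, a carboxylic acid or a plain phenyl ring without fluorine would read at this position.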